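Title: Benzamide series, sulfur substituent swap

A few compounds are considered here, and "the series" means these few. Any claim that something is new, unique, unknown or untested is made for them only; others in the source may bear on it.

Compound 1 `Nc1ccccc1NC(=O)c1ccc(CSc2cccc(F)c2)cc1` stands highest of the two numbers measured in a functional assay on A549 cells (Homo sapiens) for inhibition, read by CCK-8 assay, with a stated time of 72 h, tested at 8 uM (on this read-out higher numbers stand for more inhibition of growth at the one concentration tested and lower numbers for less inhibition of growth), where compound 1 gives 72.7%. Among the measured compounds shown here, compound 2 `Nc1ccccc1NC(=O)/C=C/c1ccc(CSCCc2ccccc2)cc1` is the only comparison on hand; in this assay compound 2 gives 50.3%, which sits below compound 1 by more than the usual scatter. For the measured compounds named here, compound 2 differs from compound 1 in more than one place, so no single step between them can be read off.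

Compound 3 `Nc1ccccc1NC(=O)c1ccc(CSCCc2ccccc2)cc1` is the unmeasured member. Against compound 1 the difference is phenethyl in place of 3-fluorophenyl on a sulfur. Compound 3 thus carries the phenethyl on sulfur that compound 2 also carries, while keeping the core of compound 1 otherwise unchanged. The value of compound 2 in this assay, 50.3%, is the only pointer to how a phenethyl on sulfur behaves here, and it is the lower of the two numbers. A downward step is therefore expected, of moderate size, possibly beyond the scatter but not certainly so.

Compound 3 is estimated at 58% in this assay, within 38% to 78%. The expected change is a number 14.7 percentage points lower from compound 1 to compound 3 (beyond the scatter).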

Compound 3, percent growth inhibition at one concentration: 84.1%
For compound 3 the middle estimate is 26.1 percentage points below the measured one; measured number above the stated range.
By their numbers in this assay, from the lowest: compound 2; then compound 1; then compound 3.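

In this assay, phenethyl in place of 3-fluorophenyl on a sulfur gives a number 11.4 percentage points higher from compound 1 to compound 3 (beyond the scatter), so on this core the sulfur carries the phenethyl without loss of growth inhibition at the one concentration tested, and the 3-fluorophenyl is not needed for a high number. A phenethyl on sulfur also does not by itself go with a low number: compound 2 carries this group and gives 50.3%, while compound 3 gives 84.1% with the same group on the core of compound 1. No measurement at hand bears on why this step goes upward, and no cause can be assigned to it.

The compounds shown leave open how far the trend at this sulfur extends, for instance to a longer chain such as 3-phenylpropyl, to an unsubstituted phenyl, or to a chain ending in an amine. They also leave open whether a fluorine on the ring of the phenethyl would raise or lower the number, and whether the order of these compounds would hold at other concentrations.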